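The compounds below may be only part of what the source reports. "The series", "measured", "known", "first", "only" and "open" are said of these compounds alone.

Of the compounds shown here, two that share one core have been tested in a functional assay on HGC-27 cells (Homo sapiens) for cytotoxicity, read by MTT assay, with a stated time of 72 h; on this read-out lower numbers stand for stronger inhibition and higher numbers for weaker inhibition. Compound 1 `CCCCCCCCCCCCNc1nc(SCc2ccc(C(F)(F)F)cc2)nc2ccccc12` gives 38700 nM in this assay. Compound 2 `O=[N+]([O-])c1cccc(Nc2nc(SCc3ccc(C(F)(F)F)cc3)nc3ccccc23)c1` gives only a limit in this assay, namely > 50000 nM, and that is the limit of > 50000 nM in this assay, at which 1 of the 2 values shown sits. Compound 2 therefore stands at the weak end of the numbers shown, and no exact number can be set against compound 1 for it. Compound 3 `Fc1ccc(Nc2nc(SCc3ccc(C(F)(F)F)cc3)nc3ccccc23)cc1Cl` has not yet been measured. It differs from compound 2 in one place: 3-chloro-4-fluorophenyl in place of 3-nitrophenyl on a nitrogen on an aromatic ring. Within the data shown here, nothing measured here bears directly on that exchange; compound 1 shows only that another group on the same nitrogen yields a weak but measurable number. For compound 3 a step of an at least 1.6-fold lower number from compound 2 to compound 3 (0.22 log units; that floor lies within the scatter) is expected, a modest move into measured territory at best. Compound 3 is expected to give about 30000 nM in this assay, most likely between 10000 nM and 80000 nM.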

Compound 3, half-maximal inhibitory concentration: 14700 nM
Estimate against measurement, compound 3: 2.0-fold (0.31 log units) above, within the range that was stated.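

In this assay, 3-chloro-4-fluorophenyl in place of 3-nitrophenyl on the nitrogen gives an at least 3.4-fold lower number from compound 2 to compound 3 (0.53 log units; beyond the scatter), so a change confined to this aromatic ring can move the number by more than the usual scatter. Both compounds carry a six-membered aromatic ring at this place, yet only compound 2 stays at the limit, so having such a ring on the nitrogen does not by itself put a compound there. The true size of the step stays unknown because the value for compound 2 is a limit and not a number: the limit of > 50000 nM in this assay, at which 1 of the 3 values shown sits.

On these data alone, whether 3-chlorophenyl or 4-fluorophenyl alone would give the same step remains open. So does the outcome with an amine or a carboxylic acid on this ring.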